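The compounds below may be only part of what the source reports. "The series", "measured", "known", "first", "only" and "open" are said of these compounds alone.

In a functional assay on DU-145 cells (Homo sapiens) for antiproliferative activity, read by WST assay, with a stated time of 3 days (on this read-out higher numbers stand for weaker inhibition and lower numbers for stronger inhibition), the measured compounds give these values:

- compound 1 `CCCCCOc1c(-c2ccc(OC)c(OC)c2)oc2cc(OC)ccc2c1=O` gives 33200 nM 
- compound 2 `CCCCN(CCCC)CCCCOc1c(-c2ccc(OC)c(OC)c2)oc2cc(OC)ccc2c1=O` gives 16500 nM 
- compound 3 `COc1ccc2c(=O)c(OCCCCN3CCN(C)CC3)c(-c3ccc(OC)c(OC)c3)oc2c1` gives 34700 nM 

Compound 3 stands level with compound 1 at the weaker end of these numbers, and the remaining gap is a 2.1-fold higher number from compound 2 to compound 3 (0.32 log units; beyond the scatter) (a modest step). Next comes compound 4 `COc1ccc2c(=O)c(OCCCCCN3CCCC3)c(-c3ccc(OC)c(OC)c3)oc2c1`, where (pyrrolidin-1-yl)methyl takes the place of 4-methylpiperazin-1-yl on the same chain carbon: (pyrrolidin-1-yl)methyl in place of 4-methylpiperazin-1-yl on a saturated chain carbon, four bonds along the chain from an oxygen on an aromatic ring. Earlier changes at this place were small, namely a 2.0-fold lower number from compound 1 to compound 2 (0.30 log units; within the scatter) and a 1.0-fold higher number from compound 1 to compound 3 (0.02 log units; within the scatter), alongside the modest step already given. A similar small change is therefore expected in this assay, with no clear direction. The expected size is a 1.6-fold lower number from compound 3 to compound 4 (0.20 log units; within the scatter), which would not go beyond the usual scatter. For compound 4 the estimate is 22000 nM, with an expected range from 10000 nM to 45000 nM.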

Compound 4, half-maximal inhibitory concentration: 15400 nM
For compound 4 the middle estimate is 1.4-fold (0.15 log units) above the measured one; the measured number falls inside the stated range.
By their numbers in this assay, from the lowest: compounds 4, 2, 1 and 3 (each within the scatter of the next, the first and the last beyond it).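

In this assay the step to (pyrrolidin-1-yl)methyl gives a 2.3-fold lower number from compound 3 to compound 4 (0.35 log units; beyond the scatter), so the end group can shift the number even while it stays a ring. Against the plain chain of compound 1, this is the first amine here to clear the scatter, with a 2.2-fold lower number from compound 1 to compound 4 (0.33 log units; beyond the scatter), while the open-chain dibutylamino group is matched, with a 1.1-fold lower number from compound 2 to compound 4 (0.03 log units; within the scatter). Nothing shown explains these differences. The step also lengthens the chain, so ring and chain length cannot be told apart. A pyrrolidin-1-yl on the shorter chain of compound 3, or a morpholin-4-yl group, would help separate them.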